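The source may report more compounds than this note shows. Statements on the series, on what has been measured and on what is new or still open speak of the compounds shown alone.

Compound 2 `CN(Cc1ccc(C2=NCCN2)cc1)C(=O)COCCN(C)S(=O)(=O)c1ccc(OC(F)(F)F)cc1` stands at the higher end of the two values in an assay on HEK293 cells for displacement of a labelled ligand from B1 bradykinin receptor (Homo sapiens), read by scintillation counting; a lower number here means a stronger inhibitor, a higher number a weaker inhibitor: compound 2 gives 85 nM, whereas compound 1 `COc1ccc(S(=O)(=O)N(C)CCOCC(=O)N(C)Cc2ccc(C3=NCCN3)cc2)c(C)c1` gives 5.5 nM. Going by the values given here, the single step in this assay, a 15-fold higher number from compound 1 to compound 2 (1.19 log units; beyond the scatter), shows that exchanging the group on the sulfonyl sulfur moves the number strongly. Compound 3 `CN(Cc1ccc(C2=NCCN2)cc1)C(=O)COCCN(C)S(=O)(=O)c1ccccc1C(F)(F)F` carries 2-(trifluoromethyl)phenyl in place of 4-(trifluoromethoxy)phenyl on a sulfonyl sulfur. Among the compounds with values here, no step matches this exchange, so its direction is open; the precedent only suggests the size could be large. Compound 3 is therefore expected to give 50 nM, within 12 nM to 200 nM, an estimated step of a 1.7-fold lower number from compound 2 to compound 3 (0.23 log units; within the scatter).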

Compound 3, inhibition constant: 2.8 nM
Estimate against measurement, compound 3: 18-fold (1.25 log units) above, outside the stated range (below it).
By their numbers in this assay, from the lowest: compounds 3 and 1 (each within the scatter of the next); then compound 2.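

Working notes: at the sulfonyl sulfur, the high number of compound 2 is not general to trifluoro-substituted aryl groups: in this assay, a 30-fold lower number from compound 2 to compound 3 (1.48 log units; beyond the scatter). Going by these compounds alone, with a 2.0-fold lower number from compound 1 to compound 3 (0.29 log units; within the scatter), 2-(trifluoromethyl)phenyl and 4-methoxy-2-methylphenyl read alike, so both groups named with a 2-substituent give low numbers, and 4-(trifluoromethoxy)phenyl is the one compound that stands apart. No measurement available here explains this difference. On these data alone, how an unsubstituted phenyl or a 2-chlorophenyl on the sulfonyl sulfur would read remains open, as does whether the 2-substituent alone sets the number.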